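Reshaping the Alkyl Branch on a Shared Core

A few compounds are considered here, and "the series" means these few. Any claim that something is new, unique, unknown or untested is made for them only; others in the source may bear on it.

Of the compounds shown here, three have been tested so far in a functional assay on the whole organism (blood, strain Wistar-Okamoto) with Rattus norvegicus as the target, with a stated time of 5 days; on this read-out higher numbers stand for an effect only at larger amounts of compound and lower numbers for an effect already at smaller amounts. Compound 1 `CCCCC(CC)C/N=C(\NC#N)Nc1cccnc1` reaches only a limit of the assay in this assay, recorded as > 50 mg/kg. Compound 2 `CCOCC/N=C(\NC#N)Nc1cccnc1` likewise reaches only a limit in this assay, given as > 20 mg/kg. Among the measured compounds shown here, compound 3 `CC(C)CC(C)/N=C(\NC#N)Nc1ccncc1` is the one member with a number in this assay, where compound 3 gives 35 mg/kg. For the measured compounds named here, it therefore stands as the only measured value among the three. No pair among these three differs in a single place, so no measured step exists to lean on.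

Compound 4 `CC(C)C(C)(C)/N=C(\NC#N)Nc1ccncc1` differs from compound 3 only in the shape of its alkyl branch: 1,1,2-trimethylpropyl in place of 1,3-dimethylbutyl on a double-bonded nitrogen. The two groups hold the same atoms, and the change is a rearrangement rather than an addition or removal. Without a measured step of this kind, the expectation is for a small change, if any, that stays within the usual scatter of repeated runs, and the direction cannot be called from the data at hand. In this assay the expected step is a 1.1-fold higher number from compound 3 to compound 4 (0.06 log units; within the scatter). Compound 4 is thus estimated to need about 40 mg/kg in this assay, with a likely range from 15 mg/kg to 100 mg/kg.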

Compound 4, minimum effective dose: 20 mg/kg
Estimate against measurement, compound 4: 2.0-fold (0.30 log units) above, and the stated range covers the measured number.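

In this assay, among the compounds shown here, swapping 1,3-dimethylbutyl for 1,1,2-trimethylpropyl gives a 1.8-fold lower number from compound 3 to compound 4 (0.24 log units; within the scatter), the first step that changes one place only. It shows that on a double-bonded nitrogen, this branch can be reshaped while keeping the same atoms without moving the result beyond what repeat measurements would give, so the two groups cannot be told apart on this read-out. Nothing measured here points to a cause for the small step, and with a step inside the scatter there is little that needs explaining.

Going by these compounds, what happens when the atoms themselves change at this place stays open, for instance with a cyclohexyl ring, a much shorter chain such as methyl, or a chain ending in a hydroxyl group. Compound 1 and compound 2 differ from compound 3 and compound 4 in more than one place, so no step can be read from them, and how much of the result rests on the rest of the shared core also remains unanswered.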